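A few compounds are considered here, and "the series" means these few. Any claim that something is new, unique, unknown or untested is made for them only; others in the source may bear on it.

Compounds with values in an ADME assay on microsomes from liver (Rattus norvegicus) for metabolic stability, with a stated time of 10 min; a lower number here means that less of the compound is left, a higher number that more of the compound is left:
- compound 1 `COc1ccc2oc(-c3cn4nc(OC)sc4n3)cc2c1`: 38%
- compound 2 `COc1cc(OCc2cccc(CCc3ccccc3)c2)c2cc(-c3cn4nc(OC)sc4n3)oc2c1`: 68%

Compound 2 has the higher of the two numbers in this assay. Its nearest neighbour is compound 1, whose number is lower by more than the usual scatter, so the two compounds are genuinely apart. Among the compounds with values here, the two differ in more than one place, so no single-change step between measured compounds is available to lean on.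

Compound 3 `COc1cc(OCc2cccc(Oc3ccccc3)c2)c2cc(-c3cn4nc(OC)sc4n3)oc2c1` has not been measured in this assay. It differs from compound 2 in one place: phenoxy in place of phenethyl on an aromatic carbon. Both groups carry a single six-membered aromatic ring of carbon only and sit on the same aromatic carbon, meta to a large group.

Within the data shown here, with no measured single-change step to guide it, the step of a number 3 percentage points lower from compound 2 to compound 3 (within the scatter) is expected to be small, likely no larger than the scatter, in either direction. Compound 3 is therefore estimated to give 65% in this assay, with a range from 45% to 85%.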

Compound 3, percent of the compound remaining: 42%
For compound 3 the middle estimate is 23 percentage points above the measured one; the whole stated range lies above it.
By their numbers in this assay, from the lowest: compounds 1 and 3 (each within the scatter of the next); then compound 2.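

In this assay, putting phenoxy in place of phenethyl gives a number 26 percentage points lower from compound 2 to compound 3 (beyond the scatter), so this spot, on an aromatic carbon meta to a large group, is sensitive to the change. Both groups carry one six-membered aromatic ring of carbon only, which means that having such a ring there does not by itself fix the number; what differs is how that ring is attached, with two carbons in phenethyl and an oxygen in phenoxy. No measurement on hand explains why the number moves.

This single change alters the heavy-atom count, the type of linking atom and the number of hydrogen-bond acceptors all at once, so the compounds shown cannot say which of these matters in this assay. Benzyl, or an amine as the link to the same ring, would be the kind of group needed to pull these apart, and a longer carbon chain would show whether the number keeps changing as the ring moves further out.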